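Swapping the bromine-bearing benzyl group for a methyl-bearing one

The compounds below may be only part of what the source reports. "The series", "measured", "known", "first", "only" and "open" are said of these compounds alone.

Of the compounds shown here, three of a shared core have been tested in an ADME assay on Huh-5-2 cells (Homo sapiens) for cytotoxicity, read by WST assay, with a stated time of 3 days; a higher number here means that more compound is tolerated, a lower number that less compound is tolerated. Compound 1 `O=c1c(OCc2ccccc2[N+](=O)[O-])c(-c2ccccc2)oc2cc(O)cc(O)c12` gives 51000 nM; compound 2 `O=c1c(OCc2cccc(Br)c2)c(-c2ccccc2)oc2cc(O)cc(O)c12` gives 15000 nM; compound 3 `O=c1c(OCc2ccc(Cl)cc2)c(-c2ccccc2)oc2cc(O)cc(O)c12` gives 36000 nM. Compound 2 stands lowest of the three: its step to compound 3 is a 2.4-fold higher number from compound 2 to compound 3 (0.38 log units; beyond the scatter), and from compound 1 the step is a 3.4-fold lower number from compound 1 to compound 2 (0.53 log units; beyond the scatter), both beyond the scatter, so compound 2 is the least tolerated compound measured here.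

Compound 4 `Cc1ccc(COc2c(-c3ccccc3)oc3cc(O)cc(O)c3c2=O)cc1` has not been measured. It differs from compound 2 by one change: 4-methylphenyl in place of 3-bromophenyl on a saturated chain carbon bound to an oxygen on an aromatic ring. Among the measured compounds shown here, the closest measured step is the one from compound 2 to compound 3, which also replaces the 3-bromophenyl group and reads a 2.4-fold higher number from compound 2 to compound 3 (0.38 log units; beyond the scatter). The change from compound 1 to compound 3, a 1.4-fold lower number from compound 1 to compound 3 (0.15 log units; within the scatter), stays within the scatter, so the core tolerates several groups at this place about equally. A modest rise is therefore expected for compound 4, about a 2.0-fold higher number from compound 2 to compound 4 (0.30 log units; within the scatter), because the replacement of 3-bromophenyl in a 2.4-fold higher number from compound 2 to compound 3 (0.38 log units; beyond the scatter) went that way. Compound 4 is thus estimated at 30000 nM, in a range from 12000 nM to 75000 nM.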

Compound 4, half-maximal cytotoxic concentration: 40000 nM
The estimate for compound 4 lay 1.3-fold (0.12 log units) below the measured number; low and high end bracket the measured number.
By their numbers in this assay, from the lowest: compound 2; then compounds 3, 4 and 1 (each within the scatter of the next).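

The 4-methylphenyl group lifts the number clearly above that of the 3-bromophenyl group, with a 2.7-fold higher number from compound 2 to compound 4 (0.43 log units; beyond the scatter), so a third group now stands apart from compound 2, which remains the least tolerated of the four. Methyl and chloro on the aromatic carbon cannot be told apart, with a 1.1-fold higher number from compound 3 to compound 4 (0.05 log units; within the scatter), and neither can the 4-methylphenyl and 2-nitrophenyl groups, with a 1.3-fold lower number from compound 1 to compound 4 (0.11 log units; within the scatter), so compounds 1, 3 and 4 form one level and only compound 2 lies lower. Nothing available explains why compound 2 differs from the others.

The 3-bromophenyl group differs from the others in both its atom and its place on the ring, so these compounds cannot show which of the two matters. Going by these compounds, a 4-bromophenyl or 3-methylphenyl group would separate them, while the effect of an amine or a carboxylic acid on this ring remains open.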